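This account rests on a few compounds, and the source may have more. Where it says the series, first, only, none or still open, it means among the compounds named here.

In an assay on isolated protein for inhibition of Aromatase (Homo sapiens), read by fluorescence, using NADPH, with a stated time of 30 min, tested at 50 uM (on this read-out lower numbers stand for less inhibition and higher numbers for more inhibition at the one concentration tested (going by the name of the read-out)), compound 1 `Cn1c(-c2ccc(Cl)c(Cl)c2)cc2cc([N+](=O)[O-])ccc21` gives 34%, compound 2 `CO/N=C/c1c(-c2ccccc2)[nH]c2ccccc12` gives 24.7% and compound 3 `C(=N/OCc1ccccc1)\c1c(-c2ccccc2)[nH]c2ccccc12` gives 23.3%. Compound 3 thus holds the lowest of the three numbers; compound 2 sits within the scatter of it, while compound 1 stands beyond the scatter above it. Compound 4 `O/N=C/c1c(-c2ccccc2)[nH]c2ccccc12` has not yet been measured in this assay. It differs from compound 3 by hydrogen in place of benzyl on an oxygen. For the measured compounds named here, the only measured step touching the same region, a number 1.4 percentage points lower from compound 2 to compound 3 (within the scatter), was within the scatter, so altering the group on the oxygen bearing the double-bonded nitrogen is expected to produce no step beyond the scatter in this assay. Compound 4 is accordingly expected to give 24%, a step of a number 0.7 percentage points higher from compound 3 to compound 4 (within the scatter), with a range from 12% to 38%.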

Compound 4, a percentage reported as inhibition, at one concentration (the size of the read-out at that concentration, not a potency): 40.4%
Compound 4: the middle estimate sits 16.4 percentage points below what was measured; measured number outside the range, above it.
By their numbers in this assay, from the lowest: compounds 3, 2, 1 and 4 (each within the scatter of the next, the first and the last beyond it).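

Hydrogen in place of benzyl on the oxygen gives a number 17.1 percentage points higher from compound 3 to compound 4 (beyond the scatter), and hydrogen in place of methyl gives a number 15.7 percentage points higher from compound 2 to compound 4 (beyond the scatter). The group on this oxygen therefore does matter: methyl and benzyl could not be told apart, yet the hydroxy compound stands clear of both. No measurement at hand accounts for this difference. Going by these compounds, it remains open whether any group on this oxygen keeps the higher number or only hydrogen does. Neither an ethyl nor an acetyl group on the oxygen, nor an amine in place of the hydroxy, is among the compounds shown.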